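The source may report more compounds than this note shows. Statements on the series, on what has been measured and on what is new or still open speak of the compounds shown alone.

The three measured compounds share one core and differ only in the group on the carbonyl carbon. Compound 1 `COc1cc(-c2nn(-c3cccc(NC(=O)c4cccc(C(F)(F)F)c4)c3)cc2-c2ccncc2)ccc1Cl` carries a 3-(trifluoromethyl)phenyl there, compound 2 `COc1cc(-c2nn(-c3cccc(NC(=O)Nc4ccc(Cl)c(Cl)c4)c3)cc2-c2ccncc2)ccc1Cl` a (3,4-dichlorophenyl)amino, and compound 3 `COc1cc(-c2nn(-c3cccc(NC(=O)c4ccc(Cl)c(C(F)(F)F)c4)c3)cc2-c2ccncc2)ccc1Cl` a 4-chloro-3-(trifluoromethyl)phenyl. In a functional assay on NCI-H23 cells (Homo sapiens) for inhibition, read by sulforhodamine B assay, with a stated time of 48 h (on this read-out higher numbers stand for lower toxicity in this test and lower numbers for higher toxicity in this test), compound 1 gives only a limit, > 50000 nM. Compound 2 likewise gives only a limit, > 50000 nM. Compound 3 also gives only a limit, > 32500 nM. Compound 3 thus stands at a limit, as do both other values. The steps a step that the two limits leave unreadable from compound 1 to compound 2, a step that the two limits leave unreadable from compound 1 to compound 3 and a step that the two limits leave unreadable from compound 2 to compound 3 cannot be sized, as the limit of > 50000 nM in this assay, at which 2 of the 3 values shown sit, and the limit of > 32500 nM in this assay, at which 1 of the 3 values shown sits, show. Compound 4 `COc1cc(-c2nn(-c3cccc(NC(=O)c4ccccc4)c3)cc2-c2ccncc2)ccc1Cl` differs from compound 3 by phenyl in place of 4-chloro-3-(trifluoromethyl)phenyl on a carbonyl carbon. Going by the values given here, no measured step bears on this change with a readable size; all three known values sit at limits, so no step beyond the scatter in this assay is expected, and compound 4 is expected to stay at a limit too. The expected step from compound 3 to compound 4 is a step that the limit leaves unreadable from compound 3 to compound 4. Compound 4 is estimated at 50000 nM, between 30000 nM and 100000 nM.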

Compound 4, concentration lethal to 50% of the cells: > 100000 nM
Compound 4: no number, only a limit; the forecaster's own chance of this, stated with the estimate: 90%; middle value at least 2.0-fold (0.30 log units) from the limit.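

In this assay compound 4 gives only a limit, > 100000 nM. Going by these compounds alone, no step between compound 4 and compound 1, compound 2 or compound 3 can be read. The compounds shown leave open whether any group on the carbonyl carbon changes the value at all: none of the four gives a number.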